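The compounds below may be only part of what the source reports. "The series", "measured", "known", "first", "only" and "open" are said of these compounds alone.

Working notes on the series, taken from compound 3 `O=C(c1cc2ccccc2o1)N1N=C(c2ccc(F)cc2)CC1c1ccccc1`. In a functional assay on A2780 cells (Homo sapiens) for antiproliferative activity, read by MTT assay, with a stated time of 72 h (on this read-out higher numbers stand for weaker inhibition and lower numbers for stronger inhibition), compound 3 gives 11.8 ug/mL. Compound 1 `O=C(c1cc2ccccc2o1)N1N=C(c2ccc(Cl)cc2)CC1c1ccccc1` gives 13.6 ug/mL, and fluoro in place of chloro on an aromatic carbon amounts to a 1.2-fold lower number from compound 1 to compound 3 (0.06 log units; within the scatter), so these two compounds cannot be told apart on this read-out. Compound 2 `COc1ccc(C2CC(c3ccc(Cl)cc3)=NN2C(=O)c2cc3ccccc3o2)cc1` gives 5.74 ug/mL, the lowest number of the three, and its value stands clear of compound 3 by more than the scatter.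

The next change leads to compound 4 `COc1ccc(C2CC(c3ccc(F)cc3)=NN2C(=O)c2cc3ccccc3o2)cc1` and is methoxy in place of hydrogen on an aromatic carbon, or phenyl to 4-methoxyphenyl when cut one bond further out. For the measured compounds named here, the only measured step of this kind is a 2.4-fold lower number from compound 1 to compound 2 (0.37 log units; beyond the scatter), a modest one, seen on the chloro member of the series. Going by the values given here, no such pair has been measured on the fluoro side, so the expectation rests on that single pair, with the chloro and fluoro members sitting level through a 1.2-fold lower number from compound 1 to compound 3 (0.06 log units; within the scatter). A step of similar size towards a lower number is therefore expected in this assay. The expected step is a 2.3-fold lower number from compound 3 to compound 4 (0.36 log units; beyond the scatter). Compound 4 is estimated at 5.2 ug/mL, with an expected range from 2.7 ug/mL to 9.5 ug/mL.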

Compound 4, half-maximal inhibitory concentration: 23 ug/mL
For compound 4 the middle estimate is 4.4-fold (0.65 log units) below the measured one, outside the stated range (above it).
By their numbers in this assay, from the lowest: compound 2; then compounds 3, 1 and 4 (each within the scatter of the next).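

In this assay, methoxy in place of hydrogen on the fluoro member gives a 1.9-fold higher number from compound 3 to compound 4 (0.29 log units; within the scatter), so the methoxy group does not separate this pair. The step seen on the chloro member therefore does not carry over to the fluoro member, and the same change reads differently on the two cores: the same change on two cores in this assay, a 2.4-fold lower number (0.37 log units; beyond the scatter) from compound 1 to compound 2 and a 1.9-fold higher number (0.29 log units; within the scatter) from compound 3 to compound 4, 4.6-fold (0.66 log units) apart, beyond the scatter of two such steps. Fluoro in place of chloro, which made no readable difference without the methoxy group, gives a 4.0-fold higher number from compound 2 to compound 4 (0.60 log units; beyond the scatter) with it, so the two places of change cannot be treated as independent in this small set: the same change on two cores in this assay, a 1.2-fold lower number (0.06 log units; within the scatter) from compound 1 to compound 3 and a 4.0-fold higher number (0.60 log units; beyond the scatter) from compound 2 to compound 4, 4.6-fold (0.66 log units) apart, beyond the scatter of two such steps.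

From the compounds shown here alone, the interaction rests on a single square of four compounds, in which compound 2 alone stands clear of the others, so it remains open whether that value reflects something specific to the pairing of chloro with methoxy or a wider trend. Also open, going by these compounds, is whether bromo in place of chloro, or hydroxy or dimethylamino in place of methoxy, would follow the chloro pair, the fluoro pair or neither.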